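Swapping a Chlorophenyl for a Hydroxyalkyl Methoxyphenyl

A few compounds are considered here, and "the series" means these few. Any claim that something is new, unique, unknown or untested is made for them only; others in the source may bear on it.

Of the compounds shown here, three built on one shared core have been tested in a functional assay on MV4-11 cells (Homo sapiens) for antiproliferative activity, read by CCK-8 assay, with a stated time of 72 h; a higher number here means a weaker inhibitor, a lower number a stronger inhibitor. Compound 1 `Cn1cc(-c2cc(C(C)(C)O)ccc2Oc2ccc(F)cc2F)c2cc(C(=O)NCc3ccc(C(=O)Nc4ccccc4N)cc3)[nH]c2c1=O` gives 90 nM, compound 2 `Cc1ccccc1-c1cn(C)c(=O)c2[nH]c(C(=O)NCc3ccc(C(=O)Nc4ccccc4N)cc3)cc12` gives 310 nM, and compound 3 `Cn1cc(-c2cccc(Cl)c2)c2cc(C(=O)NCc3ccc(C(=O)Nc4ccccc4N)cc3)[nH]c2c1=O` gives 190 nM. Compound 3 therefore stands second highest of the three numbers; its nearest neighbour is compound 2, and its furthest is compound 1, whose number lies lower beyond the scatter. Within the data shown here, the single measured step, a 1.6-fold lower number from compound 2 to compound 3 (0.21 log units; within the scatter), sits within the scatter. Compound 4 `COc1ccc(C(C)(C)O)cc1-c1cn(C)c(=O)c2[nH]c(C(=O)NCc3ccc(C(=O)Nc4ccccc4N)cc3)cc12` differs from compound 3 in one place: 5-(1-hydroxy-1-methylethyl)-2-methoxyphenyl in place of 3-chlorophenyl on an aromatic carbon. The entering group carries the 1-hydroxy-1-methylethyl also present in compound 1, the lowest number shown, but no step links compound 1 to compound 3, so the expectation rests only loosely on that value. Compound 4 is expected to give about 120 nM, with a range from 50 nM to 300 nM. The expected step of a 1.6-fold lower number from compound 3 to compound 4 (0.20 log units; within the scatter) is estimated to fall at the edge of the scatter.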

Compound 4, half-maximal inhibitory concentration: 420 nM
The estimate for compound 4 lay 3.5-fold (0.54 log units) below the measured number, outside the stated range (above it).
By their numbers in this assay, from the lowest: compound 1; then compounds 3, 2 and 4 (each within the scatter of the next, the first and the last beyond it).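

The 5-(1-hydroxy-1-methylethyl)-2-methoxyphenyl group does not by itself bring a lower number at this position: in place of 3-chlorophenyl it gives a rise (a 2.2-fold higher number from compound 3 to compound 4 (0.34 log units; beyond the scatter)), and in place of 2-methylphenyl it gives no clear change (a 1.4-fold higher number from compound 2 to compound 4 (0.13 log units; within the scatter)). The group on the oxygen also counts, since methyl in place of 2,4-difluorophenyl gives a further rise (a 4.7-fold higher number from compound 1 to compound 4 (0.67 log units; beyond the scatter)). Nothing available explains these shifts. Still open, on these data alone, is how an ethyl or a plain phenyl on that oxygen would compare.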